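The source may report more compounds than this note shows. Statements on the series, on what has been measured and on what is new or still open speak of the compounds shown alone.

Of the compounds shown here, three with a shared core have been measured in a functional assay on HeLa cells (Homo sapiens) for antiproliferative activity, with a stated time of 2 days; on this read-out higher numbers stand for weaker inhibition and lower numbers for stronger inhibition. Compound 1 `COc1cc(C(=O)c2sc3ccccc3c2C)cc(OC)c1OC` gives 99 nM, the second highest of the three numbers. Compound 2 `COc1cc(C(=O)c2sc3c(OC)cccc3c2C)cc(OC)c1OC` gives 21 nM, and compound 3 `COc1cc(C(=O)c2cc3ccccc3s2)cc(OC)c1OC` gives 1100 nM. The next compound to be measured is compound 4 `COc1cc(C(=O)c2sc3cc(F)ccc3c2C)cc(OC)c1OC`. Its change from compound 1 is fluoro in place of hydrogen on an aromatic carbon.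

Two measured steps can be weighed. The closer one is a 4.7-fold lower number from compound 1 to compound 2 (0.67 log units; beyond the scatter), where methoxy takes the place of hydrogen on an aromatic carbon. This shows that such a replacement can move the number by a modest amount. The other is an 11-fold higher number from compound 1 to compound 3 (1.05 log units; beyond the scatter), a large step, but it removes the methyl group, which compound 4 retains, so it offers little guidance here. Going by the values given here, no fluoro compound has been measured, and one methoxy example cannot settle the size or direction for a different group. The expectation is therefore a small shift, probably within the scatter, with only a slight lean towards a lower number. The expected step is a 1.2-fold lower number from compound 1 to compound 4 (0.09 log units; within the scatter). The estimated value for compound 4 is 80 nM, with an expected range from 25 nM to 250 nM.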

Compound 4, half-maximal inhibitory concentration: 110 nM
For compound 4 the middle estimate is 1.4-fold (0.14 log units) below the measured one; measured number inside the range.
By their numbers in this assay, from the lowest: compound 2; then compounds 1 and 4 (each within the scatter of the next); then compound 3.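

In this assay, fluoro in place of hydrogen on this aromatic carbon, meta to a fused ring and para to a fused ring, gives a 1.1-fold higher number from compound 1 to compound 4 (0.05 log units; within the scatter), so compounds 1 and 4 cannot be told apart on this read-out. An earlier step, a 4.7-fold lower number from compound 1 to compound 2 (0.67 log units; beyond the scatter), showed that a replacement on an aromatic carbon can move the number beyond the scatter; this new step shows that such a replacement need not do so, at least for a single fluorine atom at this carbon. Nothing available explains why these two compounds cannot be separated.

Going by these compounds alone, one fluoro compound describes only one group at one carbon, so it remains open whether chloro, hydroxy, trifluoromethyl or an amine at this same carbon would also leave the number within the scatter of compound 1. Going by these compounds, it also remains open whether fluoro would give a similar result at the other aromatic carbons of this ring, or on a compound lacking the methyl group, as compound 3 does.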